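Amide replacement at the carbonyl carbon of the shared core

The source may report more compounds than this note shows. Statements on the series, on what has been measured and on what is new or still open speak of the compounds shown alone.

Measured compounds:
compound 1, `CCN(CC)S(=O)(=O)c1ccc(S(=O)(=O)N2CCC[C@@H](C(=O)N3CCS(=O)(=O)CC3)C2)cc1` — 4430 nM
compound 2, `CCN(CC)S(=O)(=O)c1ccc(S(=O)(=O)N2CCC[C@@H](C(=O)NC3COC3)C2)cc1` — 13800 nM

In a functional assay on BXPC-3 cells (Homo sapiens) for inhibition, read by MTT assay, with a stated time of 7 days (on this read-out higher numbers stand for weaker inhibition and lower numbers for stronger inhibition), compound 2 gives the highest of the two numbers shown; its nearest neighbour, compound 1, stands apart by a 3.1-fold higher number from compound 1 to compound 2 (0.49 log units; beyond the scatter). Compound 3, `CCN(CC)S(=O)(=O)c1ccc(S(=O)(=O)N2CCC[C@@H](C(=O)N3CCC(C(F)(F)F)CC3)C2)cc1`, has not been measured; it differs from compound 2 by 4-(trifluoromethyl)piperidin-1-yl in place of (oxetan-3-yl)amino on a carbonyl carbon. Going by the values given here, the only measured step bears on the same carbonyl carbon, where a 3.1-fold higher number from compound 1 to compound 2 (0.49 log units; beyond the scatter) accompanied a change of the group attached there; no step involving a 4-(trifluoromethyl)piperidin-1-yl group is available. Among the compounds with values here, since the one recorded change at this position moved the number modestly, and compound 3 returns to a ring attached through its nitrogen as in compound 1, a modest step back toward compound 1 is expected, a 2.5-fold lower number from compound 2 to compound 3 (0.40 log units; beyond the scatter), though the data are too thin to be sure. Compound 3 is therefore estimated at 5500 nM, with a range of 1500 nM to 18000 nM.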

Compound 3, half-maximal inhibitory concentration: 370 nM
Compound 3: middle estimate off by 15-fold (1.17 log units), on the high side, outside the stated range (below it).
By their numbers in this assay, from the lowest: compound 3; then compound 1; then compound 2.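

In this assay, going by these compounds alone, the group on this carbonyl carbon turns out to matter far more than the one earlier step showed: bringing in 4-(trifluoromethyl)piperidin-1-yl gives a 37-fold lower number from compound 2 to compound 3 (1.57 log units; beyond the scatter) and a 12-fold lower number from compound 1 to compound 3 (1.08 log units; beyond the scatter) at the same place. Compound 1 and compound 3 both join the carbonyl carbon through a ring nitrogen, so that shared feature alone does not set the number; what lies on the ring also counts. Nothing in the information given accounts for the size of this gain.

The compounds shown leave open whether the gain belongs to the trifluoromethyl group or to the piperidine ring carrying it; a plain piperidin-1-yl or a 4-methylpiperidin-1-yl group on the same carbonyl carbon would separate the two. On these data alone, how an open-chain amine such as diethylamino would stand there also remains open.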